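Fluoro removal on the benzoyl arm of compound 1

The compounds below may be only part of what the source reports. "The series", "measured", "known", "first", "only" and "open" are said of these compounds alone.

Measured so far in a functional assay on MGC-803 cells (Homo sapiens) for cytotoxicity, read by MTT assay, with a stated time of 72 h; a higher number here means a weaker inhibitor, a lower number a stronger inhibitor:
compound 1, `COc1cc2ncnc(NNC(=S)NC(=O)c3ccccc3F)c2cc1OC`: 2390 nM
compound 2, `O=C(NC(=S)NNc1ncnc2ccccc12)c1ccc(F)cc1`: 3600 nM

Compound 1 has the lower of the two numbers, but compound 2 sits only a little higher and the gap between the two is within the scatter, so no order can be read from them. Within the data shown here, compound 1 and compound 2 differ in more than one place, so they give no clean step to lean on.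

Compound 3 `COc1cc2ncnc(NNC(=S)NC(=O)c3ccccc3)c2cc1OC` is not yet measured. It differs from compound 1 in a single spot: hydrogen in place of fluoro on an aromatic carbon. Nothing measured in the series tells how this particular change plays out. With only one heavy atom leaving and a hydrogen entering, the step in this assay from compound 1 to compound 3 is expected to be small, in no set direction, and not beyond the scatter. Compound 3 is therefore estimated at 2600 nM, with a range of 1200 nM to 5500 nM. The expected step is a 1.1-fold higher number from compound 1 to compound 3 (0.04 log units; within the scatter), in effect flat.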

Compound 3, half-maximal inhibitory concentration: 3050 nM
Beside the measured number, compound 3's estimate is 1.2-fold (0.07 log units) below it, within the range that was stated.
By their numbers in this assay, from the lowest: compounds 1, 3 and 2 (each within the scatter of the next).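

In this assay, among these compounds, hydrogen in place of fluoro on this aromatic carbon, ortho to a large group, gives a 1.3-fold higher number from compound 1 to compound 3 (0.11 log units; within the scatter) as the first clean single-place step, so the two numbers cannot be told apart. The fluoro at this position is therefore not required for a number in this range, as compound 3, which carries a plain benzoyl, reads alike with compound 1 within the scatter. No supporting measurement bears on this result, so the step comes with no account of what lies behind it.

From the compounds shown here alone, it remains open whether this aromatic carbon accepts only a small replacement or whether a larger group, such as an amine or a carboxylic acid, would shift the number beyond the scatter. Compound 1 and compound 2 still differ in more than one place, so the position of the fluoro on the benzoyl arm and the methoxy groups on the shared core cannot be read separately from that pair.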